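This account rests on a few compounds, and the source may have more. Where it says the series, first, only, none or still open, it means among the compounds named here.

Of the compounds shown here, two have been measured so far in a functional assay on EC9706 cells (Homo sapiens) for antiproliferative activity, read by MTT assay, with a stated time of 48 h; a lower number here means a stronger inhibitor, a higher number a weaker inhibitor. Compound 2 (`CCCCCCCCCCCCCCn1cc(COC[C@@H]2OC[C@H](N)[C@H]2O)nn1`) gives 6680 nM, the lower and therefore stronger of the two numbers. Compound 1 (`CCCCCCCCCCCCCCCCCCn1cc(COC[C@@H]2OC[C@H](N)[C@@H]2O)nn1`) gives 17800 nM, and that gap lies beyond the usual scatter of repeat measurements.

The next compound to consider is compound 3 (`CCCCCCCCCCCCCCCCCCn1cc(COC[C@@H]2OC[C@H](N)[C@H]2O)nn1`). Relative to compound 2, its structure changes as follows: butyl in place of hydrogen on a saturated chain carbon, ten or more bonds along the chain from an aromatic nitrogen.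

Going by the values given here, no pair of measured compounds shows the effect of this change on its own, so any forecast is uncertain. Among the compounds with values here, with only two values available, the reasoning rests on the range they span, and compound 1 at 17800 nM marks its weaker end. A moderate move toward weaker inhibition is expected, although a result within the scatter would not be surprising. The estimated change is a 1.6-fold higher number from compound 2 to compound 3 (0.22 log units; within the scatter). The expected value for compound 3 is 11000 nM, within an estimated range of 4500 nM to 26000 nM.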

Compound 3, half-maximal inhibitory concentration: 2290 nM
Beside the measured number, compound 3's estimate is 4.8-fold (0.68 log units) above it, and the stated range ends above it.
By their numbers in this assay, from the lowest: compound 3; then compound 2; then compound 1.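

In this assay, butyl in place of hydrogen on a saturated chain carbon, ten or more bonds along the chain from an aromatic nitrogen, gives stronger inhibition, with a 2.9-fold lower number from compound 2 to compound 3 (0.46 log units; beyond the scatter). Going by these compounds alone, this is the first direct view of that change, and it shows that the read-out still responds to a change this far along the chain, with compound 3 now the strongest of the three. The configuration of the core counts as well, with a 7.8-fold lower number from compound 1 to compound 3 (0.89 log units; beyond the scatter), and this step can be assigned to the stereocentre at a saturated ring carbon, drawn S in compound 1 and R in compound 3, because nothing else separates the pair: the fact that compounds 1 and 3 differ only in the configuration as drawn

On these data alone, whether a longer chain would strengthen inhibition further or weaken it remains open, as one step along the chain cannot show a trend. As far as these compounds go, it is also open how the other stereocentres contribute, and how a chain ending in a carboxylic acid or an amine would compare with the plain carbon chains seen here.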